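Cyclopropylmethyl to ethyl on the aryl amine nitrogen

A few compounds are considered here, and "the series" means these few. Any claim that something is new, unique, unknown or untested is made for them only; others in the source may bear on it.

Measured compounds:
Compound 1, `COc1cc(N(CC2CC2)c2ccc(Cl)c(Cl)c2)cnc1C(=O)[C@H]1C[C@@H]1C(=O)O`, gives 4.94 nM in an assay for inhibition of leukotriene C4 synthase (Homo sapiens), read by LC-MS, with stated times of 15 min and 30 min; on this read-out lower numbers stand for stronger inhibition and higher numbers for weaker inhibition.
Compound 2, `COc1nc(C(=O)[C@@H]2C[C@H]2C(=O)O)ncc1N(CC1CC1)c1ccc(Cl)c2ccccc12`, gives 15.5 nM in this assay.
Compound 3, `COc1cc(N(CC2CC2)c2ccc(F)c3ccccc23)cnc1C(=O)[C@H]1C[C@@H]1C(=O)O`, gives 0.758 nM in this assay.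

Among the three, compound 3 holds the lowest number, and the gaps to compound 1 and to compound 2 are both beyond the usual scatter, so compound 3 is the most potent of the set. Compound 1 stands nearer to it, compound 2 furthest away.

Compound 4, `CCN(c1cnc(C(=O)[C@H]2C[C@@H]2C(=O)O)c(OC)c1)c1ccc(F)c2ccccc12`, has not yet been measured. It keeps the whole of compound 3 apart from one change: methyl in place of cyclopropyl on a saturated chain carbon bound to a nitrogen on an aromatic ring. The substituent on the nitrogen attached to the aromatic ring thus shrinks from cyclopropylmethyl to ethyl.

For the measured compounds named here, no measured pair in this set shows what such a shortening does here, so the expectation rests on the change alone. Compound 4 is expected to stay a strong inhibitor but to lose some ground against compound 3, a step of a 3.3-fold higher number from compound 3 to compound 4 (0.52 log units; beyond the scatter) that is modest yet likely beyond the scatter. The estimate for compound 4 is 2.5 nM, with a range from 0.8 nM to 8 nM.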

Compound 4, half-maximal inhibitory concentration: 1.05 nM
Beside the measured number, compound 4's estimate is 2.4-fold (0.38 log units) above it; the measured number falls inside the stated range.
By their numbers in this assay, from the lowest: compounds 3 and 4 (each within the scatter of the next); then compound 1; then compound 2.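

For the compounds shown here, compounds 3 and 4 form the first pair in the set that differs in only one place, so they give the first direct reading of this position. In this assay, methyl in place of cyclopropyl on a saturated chain carbon bound to a nitrogen on an aromatic ring gives a 1.4-fold higher number from compound 3 to compound 4 (0.14 log units; within the scatter), showing that the three-membered ring can leave this position without a change in the number that exceeds the scatter, and that ethyl serves here as well as cyclopropylmethyl. Nothing in the data shown explains why the two compounds read alike.

The compounds shown leave open how far this tolerance extends, since a longer chain such as propyl or butyl, a branched group such as isopropyl, a chain ending in a hydroxyl group or an amine, and a bare methyl on the nitrogen all lie outside this set. Going by these compounds alone, they also leave open whether the same shortening would read alike with the other groups on that nitrogen in compound 1 and compound 2, as no pair tests it there.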